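A tert-butoxy group replaces cyclopropyl on the carbonyl

The source may hold more compounds than are shown below. What is called first, only, known or untested is meant among the compounds shown, and "the series" means these compounds.

In a functional assay on SU-DHL-6 cells (Homo sapiens) for antiproliferative activity, read by CCK-8 assay, with a stated time of 72 h (a higher number here means a weaker inhibitor, a lower number a stronger inhibitor), compound 1 (`COc1ncc(-c2ccc3ncnc(NCCN4CCCCC4)c3c2)cc1NS(C)(=O)=O`) gives 320 nM. Compound 3 (`COc1ncc(-c2ccc3ncnc(N[C@H]4CCN(C(=O)C5CC5)C4)c3c2)cc1NS(C)(=O)=O`) gives 3000 nM, the higher of the two actual numbers, with a 9.4-fold higher number from compound 1 to compound 3 (0.97 log units; beyond the scatter). Compound 2 (`COc1ncc(-c2ccc3ncnc(N[C@H]4CCN(C(C)=O)C4)c3c2)cc1NS(C)(=O)=O`) reads >= 100000 nM, which is a limit of the assay and not a number.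

Compound 4 (`COc1ncc(-c2ccc3ncnc(N[C@H]4CCN(C(=O)OC(C)(C)C)C4)c3c2)cc1NS(C)(=O)=O`) has tert-butoxy in place of cyclopropyl on a carbonyl carbon. Among the measured compounds shown here, the one measured change at this carbon, cyclopropyl in place of methyl, was large, with an at least 33-fold lower number from compound 2 to compound 3 (1.52 log units; beyond the scatter). That single step shows the place matters, but it does not test tert-butoxy. In this assay, the expected step is a 1.5-fold lower number from compound 3 to compound 4 (0.18 log units; within the scatter), with no change beyond the scatter expected. Compound 4 is estimated at 2000 nM, with an expected range from 400 nM to 12000 nM.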

Compound 4, half-maximal inhibitory concentration: 170 nM
For compound 4 the middle estimate is 12-fold (1.07 log units) above the measured one; measured number below the stated range.
By their numbers in this assay, from the lowest: compounds 4 and 1 (each within the scatter of the next); then compound 3. At a limit, above all of these: compound 2.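

In this assay, the carbonyl carbon responds to more than growth from methyl: the ringless tert-butoxy outperforms cyclopropyl, with an 18-fold lower number from compound 3 to compound 4 (1.25 log units; beyond the scatter). The 1-(tert-butoxycarbonyl)pyrrolidin-3-yl group also matches the 2-(piperidin-1-yl)ethyl group, with a 1.9-fold lower number from compound 1 to compound 4 (0.27 log units; within the scatter), a difference within the scatter. The widest step, an at least 580-fold lower number from compound 2 to compound 4 (2.76 log units; beyond the scatter), gives only a bound, as compound 2 reads at a limit of the assay: the limit of >= 100000 nM in this assay, at which 1 of the 4 values shown sits.

The compounds shown do not separate the oxygen of tert-butoxy from its branched carbons. A tert-butyl or a methoxy group on the carbonyl would tell these apart.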